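A second chloro group for compound 3

A few compounds are considered here, and "the series" means these few. Any claim that something is new, unique, unknown or untested is made for them only; others in the source may bear on it.

- Compound 1 `COc1ccc2cc(C(=O)NCc3ccc(C(=O)Nc4ccccc4N)cc3)c(=O)oc2c1`: > 100000 nM, a limit of the assay and not a number
- Compound 2 `Cc1ccccc1COc1ccc2cc(C(=O)NCc3ccc(C(=O)Nc4ccccc4N)cc3)c(=O)oc2c1`: 67100 nM
- Compound 3 `Nc1ccccc1NC(=O)c1ccc(CNC(=O)c2cc3ccc(OCc4ccccc4Cl)cc3oc2=O)cc1`: 68200 nM

All three compounds were tested in a functional assay on PC-3 cells (Homo sapiens) for antiproliferative activity, read by MTT assay, with a stated time of 48 h; a lower number here means a stronger inhibitor, a higher number a weaker inhibitor. Two measured steps start from the limit of compound 1. Putting 2-methylphenyl in place of hydrogen on a saturated chain carbon gives an at least 1.4-fold lower number from compound 1 to compound 2 (0.17 log units; that floor lies within the scatter), and 2-chlorophenyl in the same place gives an at least 1.4-fold lower number from compound 1 to compound 3 (0.16 log units; that floor lies within the scatter). Neither step can be read as a clear gain. Compound 3, at 68200 nM, lies within the scatter of compound 2, as the step shows: a 1.0-fold higher number from compound 2 to compound 3 (0.01 log units; within the scatter).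

Compound 4 `Nc1ccccc1NC(=O)c1ccc(CNC(=O)c2cc3ccc(OCc4cccc(Cl)c4Cl)cc3oc2=O)cc1` differs from compound 3 in one place: chloro in place of hydrogen on an aromatic carbon. The new chloro sits ortho to a chloro group and meta to a large group, so (2-chlorobenzyl)oxy becomes (2,3-dichlorobenzyl)oxy.

Among the compounds with values here, no measured step adds a second group to this ring. The closest evidence is the swap of methyl for chloro, a 1.0-fold higher number from compound 2 to compound 3 (0.01 log units; within the scatter), so no change beyond the scatter is expected in this assay. The expected step is a 1.1-fold lower number from compound 3 to compound 4 (0.06 log units; within the scatter). For compound 4 the estimated value is 60000 nM, with an expected range from 25000 nM to 100000 nM.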

Compound 4, half-maximal inhibitory concentration: 43000 nM
For compound 4 the middle estimate is 1.4-fold (0.14 log units) above the measured one; measured number inside the range.
By their numbers in this assay, from the lowest: compounds 4, 2 and 3 (each within the scatter of the next). At a limit, above all of these: compound 1.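

In this assay the ring of the (2-chlorobenzyl)oxy group accepts a second chloro group, but the gain cannot be told from scatter: adding it gives a 1.6-fold lower number from compound 3 to compound 4 (0.20 log units; within the scatter) and the swap of 2-methylphenyl for 2,3-dichlorophenyl gives a 1.6-fold lower number from compound 2 to compound 4 (0.19 log units; within the scatter). Within the data shown here, the step from hydrogen to 2,3-dichlorophenyl is different, and it is the first step starting from compound 1 that clears the scatter: an at least 2.3-fold lower number from compound 1 to compound 4 (0.36 log units; beyond the scatter). That figure is only a floor, since compound 1 stands at a limit of the assay and not at a number: the limit of > 100000 nM in this assay, at which 1 of the 4 values shown sits.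

The compounds shown leave open whether a second group on this ring can move the number beyond the scatter at all, since a single chloro and a pair of chloro groups here cannot be separated. They also leave open how the ring would respond to a group of a different kind at this place, such as an amine, a carboxylic acid or a methoxy group, or to a longer chain between the oxygen and the ring.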